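Working notes: carboxymethyl in place of carboxy

The source may hold more compounds than are shown below. What is called first, only, known or untested is meant among the compounds shown, and "the series" means these compounds.

Measured in a functional assay on PC-3 cells (Homo sapiens) for cytotoxicity, read by MTT assay, with a stated time of 48 h; on this read-out lower numbers stand for stronger inhibition and higher numbers for weaker inhibition:
Compound 1 `O=C(O)CN1C(=O)/C(=C/c2nc3ccccc3n2Cc2ccc([N+](=O)[O-])cc2)SC1=S` gives 8270 nM
Compound 2 `O=C(O)CN1C(=O)/C(=C/c2nc3ccccc3n2Cc2ccccc2F)SC1=S` gives 1860 nM
Compound 3 `O=C(O)CN1C(=O)/C(=C/c2nc3ccc(Cl)cc3n2Cc2ccccc2F)SC1=S` gives 17300 nM

Compound 2 has the lowest of the three numbers. The change to compound 4 `O=C(O)CCN1C(=O)/C(=C/c2nc3ccccc3n2Cc2ccccc2F)SC1=S` is carboxymethyl in place of carboxy on a saturated chain carbon bound to an amide-type nitrogen in a ring. Neither measured step touches this place, so both bear only loosely. They give a scale for single changes in this series: a 4.4-fold lower number from compound 1 to compound 2 (0.65 log units; beyond the scatter) and a 9.3-fold higher number from compound 2 to compound 3 (0.97 log units; beyond the scatter) are both modest. A modest step at most is therefore expected in this assay and it may stay within the scatter. A higher number is slightly favoured, as compound 2 (1860 nM) already stands lowest. The expected step is a 1.5-fold higher number from compound 2 to compound 4 (0.18 log units; within the scatter) in this estimate. For compound 4 the estimated value is 2800 nM with 900 nM to 9000 nM as the expected range.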

Compound 4, half-maximal inhibitory concentration: 28600 nM
Estimate against measurement, compound 4: 10-fold (1.01 log units) below, and the stated range ends below it.
By their numbers in this assay, from the lowest: compound 2; then compound 1; then compounds 3 and 4 (each within the scatter of the next).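

In this assay, carboxymethyl in place of carboxy on a saturated chain carbon bound to an amide-type nitrogen in a ring gives a 15-fold higher number from compound 2 to compound 4 (1.19 log units; beyond the scatter) as a large step. The earlier compounds shown here left this place untouched, and it now proves sensitive to one added chain carbon, although both groups carry the same hydrogen-bond donor and acceptor counts. Nothing available gives a reason for this step.

The compounds shown leave open whether the number keeps rising with a longer chain such as 3-carboxypropyl. They also leave open how a primary amide or a methyl ester would behave here in place of the carboxylic acid.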